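Removing the urea link: from compound 3 to a plain benzamide

The source may report more compounds than this note shows. Statements on the series, on what has been measured and on what is new or still open speak of the compounds shown alone.

Compounds measured in an assay on CHO cells for displacement of a labelled ligand from adenosine receptor A1 (Homo sapiens), tested at 10 uM; a lower number here means less inhibition, a higher number more inhibition at the concentration tested (going by the name of the read-out):
- compound 1, `COc1ccc(C(=O)Nc2nn(-c3ccccc3)c(=O)c3ccccc23)cc1`: 0%
- compound 2, `O=C(Nc1ccccc1)Nc1nn(-c2ccccc2)c(=O)c2ccccc12`: 44%
- compound 3, `Cc1ccccc1NC(=O)Nc1nn(-c2ccccc2)c(=O)c2ccccc12`: 20%

All three share one core; they differ only in the group attached to the carbonyl carbon. Compound 3 stands second of the three numbers: it lies above compound 1 by a number 20 percentage points higher from compound 1 to compound 3 (beyond the scatter) and below compound 2 by a number 24 percentage points lower from compound 2 to compound 3 (beyond the scatter).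

Compound 4, `O=C(Nc1nn(-c2ccccc2)c(=O)c2ccccc12)c1ccccc1`, has not yet been measured. Relative to compound 3 the change is: phenyl in place of (2-methylphenyl)amino on a carbonyl carbon. In short, the amide-type nitrogen that joined the carbonyl to the ring disappears, and the ring now sits directly on the carbonyl, as it does in compound 1.

For the measured compounds named here, two measured steps bear on this. Going by the values given here, compound 1, the one compound with a ring directly on the carbonyl, gives the lowest number, and turning it into a ring joined through nitrogen raised the read-out by a number 44 percentage points higher from compound 1 to compound 2 (beyond the scatter) and by a number 20 percentage points higher from compound 1 to compound 3 (beyond the scatter). Going the other way, from compound 3 to compound 4, is therefore expected to lower the number, by about a number 12 percentage points lower from compound 3 to compound 4 (beyond the scatter). Compound 1 carries a methoxy group that compound 4 lacks, so the drop need not be complete. Compound 4 is estimated to give 8% in this assay, within 0% to 30%.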

Compound 4, a percentage reported as inhibition, at one concentration (the size of the read-out at that concentration, not a potency): 44%
Compound 4: the middle estimate sits 36 percentage points below what was measured; measured number outside the range, above it.
By their numbers in this assay, from the lowest: compound 1; then compound 3; then compounds 2 and 4 (each within the scatter of the next).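

Swapping anilino for phenyl on the carbonyl carbon gives no change at the digits printed from compound 2 to compound 4 (within the scatter) in this assay, so among these compounds a ring joined through nitrogen holds no advantage over a ring sitting directly on the carbonyl. The low reading of compound 1 therefore goes with its methoxy group, not with the missing nitrogen: hydrogen in place of methoxy gives a number 44 percentage points higher from compound 1 to compound 4 (beyond the scatter). Compound 3 also falls short of the plain phenyl, with phenyl in place of (2-methylphenyl)amino giving a number 24 percentage points higher from compound 3 to compound 4 (beyond the scatter), so the earlier link between the nitrogen and a higher number does not hold.

Nothing measured here explains why these changes act as they do. Going by these compounds, whether an amine or a carboxylic acid in place of the methoxy would also give a low number remains open.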